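The source may report more compounds than this note shows. Statements on the series, on what has been measured and on what is new or still open speak of the compounds shown alone.

Measured so far in a functional assay for agonist activity at G protein-coupled receptor 88 (Homo sapiens), read by HTRF and cAMP accumulation; a lower number here means that less compound is needed, a higher number that more compound is needed for the effect:
- compound 1, `CC(C)CCNCCN(C(=O)[C@@H]1C[C@H]1c1ccccc1)c1ccc(-c2ccccc2)cc1`: compound 1 gives 5.1 nM
- compound 2, `O=C([C@@H]1C[C@H]1c1ccccc1)N(CCNCC1CCCC1)c1ccc(-c2ccccc2)cc1`: compound 2 gives 2.5 nM
- compound 3, `CC[C@H](C)[C@H](N)CN(C(=O)[C@@H]1C[C@H]1c1ccccc1Cl)c1ccc(-c2ccccc2)cc1`: compound 3 gives > 25000 nM

Going by the values given here, compound 3 stands apart from the other two: its value is a limit of this assay and not a number, so the assay reports only that the true value lies beyond the tested range (the limit of > 25000 nM in this assay, at which 1 of the 3 values shown sits). Among the compounds with values here, compounds 1 and 2 carry a different side chain and a different cyclopropyl substituent, and the one measured step between them, a 2.0-fold lower number from compound 1 to compound 2 (0.31 log units; beyond the scatter), concerns the amine end only.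

Compound 4, `CC[C@H](C)[C@H](N)CN(C(=O)[C@@H]1C[C@H]1c1cccnc1)c1ccc(-c2ccccc2)cc1`, is the next compound to be measured. It differs from compound 3 in one place: pyridin-3-yl in place of 2-chlorophenyl on a saturated ring carbon. Within the data shown here, no measured step touches this part of the structure, since the step from compound 1 to compound 2 alters only the amine substituent; it therefore gives no guide to the direction or size of the change here. Among the measured compounds shown here, the only anchor is compound 3 itself, which sits at the limit.

On that basis, compound 4 is expected to remain at or near the limit; the estimated step of a number no higher from compound 3 to compound 4 (the limit leaves the size open) is essentially none that the data can support. The estimate for compound 4 is 25000 nM, within 3000 nM to 100000 nM.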

Compound 4, half-maximal effective concentration: 1500 nM
Beside the measured number, compound 4's estimate is 17-fold (1.22 log units) above it; measured number below the stated range.
By their numbers in this assay, from the lowest: compound 2; then compound 1; then compound 4. At a limit, above all of these: compound 3.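

In this assay, the group on the saturated ring carbon of the three-membered ring proves to be a strong handle: pyridin-3-yl in place of 2-chlorophenyl gives an at least 16-fold lower number from compound 3 to compound 4 (1.22 log units; beyond the scatter). Going by these compounds alone, compound 3 stands at a limit and not at a number: the limit of > 25000 nM in this assay, at which 1 of the 4 values shown sits. The one earlier step concerned the amine end only, so this is the first reading at this position, and it shows that, with the side chain shared by these two compounds, this substituent alone can make the difference to a measurable value. Compound 4 gives 1500 nM.

The change removes the chlorine and brings in a ring nitrogen at the same time, so the two cannot be told apart here; plain phenyl on the same side chain would separate them. Going by these compounds, how a pyrimidinyl or thienyl group would read at this place stays open, as does whether the step carries over to the amine side chains of compound 1 and compound 2.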